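Notes on compound 3 ahead of its measurement

This account rests on a few compounds, and the source may have more. Where it says the series, first, only, none or still open, it means among the compounds named here.

Measured so far in a functional assay on HCT-116 cells (Homo sapiens) for inhibition, read by sulforhodamine B assay, with a stated time of 72 h; on this read-out lower numbers stand for stronger inhibition and higher numbers for weaker inhibition:
compound 1 `COc1ccc(C(=O)/C=C/c2cn(-c3ccccc3)nc2-c2ccsc2)c(OC)c1OC`: 5800 nM
compound 2 `COc1ccc(C(=O)/C=C/c2cn(-c3ccccc3)nc2-c2ccsc2)cc1OC`: 1600 nM

Compound 1 gives the higher of the two numbers; its nearest neighbour is compound 2, reached by a 3.6-fold lower number from compound 1 to compound 2 (0.56 log units; beyond the scatter). Compound 3 `COc1ccc(C(=O)/C=C/c2cn(-c3ccccc3)nc2-c2cccnc2)c(OC)c1OC` differs from compound 1 by pyridin-3-yl in place of thiophen-3-yl on an aromatic carbon. Among the compounds with values here, no measured step touches this position: the only measured step, a 3.6-fold lower number from compound 1 to compound 2 (0.56 log units; beyond the scatter), concerns a methoxy group elsewhere and says nothing about a thiophen-3-yl to pyridin-3-yl exchange. With no guide to direction, no step beyond the scatter is expected in this assay, and no change at the digits printed from compound 1 to compound 3 (within the scatter) is the estimated change. Compound 3 is therefore estimated at 5800 nM, within 2000 nM to 17000 nM.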

Compound 3, half-maximal inhibitory concentration: 1100 nM
For compound 3 the middle estimate is 5.3-fold (0.72 log units) above the measured one, and the stated range ends above it.
By their numbers in this assay, from the lowest: compounds 3 and 2 (each within the scatter of the next); then compound 1.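

Within the data shown here, at this position the aromatic ring matters: in this assay, pyridin-3-yl in place of thiophen-3-yl gives a 5.3-fold lower number from compound 1 to compound 3 (0.72 log units; beyond the scatter), the first measured step here. The exchange of one aromatic ring for another at this carbon is therefore not silent, and the direction favours pyridin-3-yl over thiophen-3-yl in this pair. No evidence on the origin of this step is at hand.

From the compounds shown here alone, whether the same step holds with the methoxy pattern of compound 2 remains open. Also open, going by these compounds, is how a plain phenyl group, or a pyridine ring carrying an amine or a carboxylic acid, would read at this carbon.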